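The compounds below may be only part of what the source reports. "The series", "measured", "known", "first", "only" and "open" are said of these compounds alone.

Measured in a functional assay on SH-SY5Y cells (Homo sapiens) for cytotoxicity, read by MTT assay, with a stated time of 72 h; a lower number here means a stronger inhibitor, a higher number a weaker inhibitor:
- Compound 1 `[O-][S+](CCCCN=C=S)Cc1ccccc1`: 5210 nM
- Compound 2 `O=[N+]([O-])c1ccc(C[S+]([O-])CCCCN=C=S)cc1`: 7230 nM
- Compound 3 `COc1ccc(C[S+]([O-])CCCCN=C=S)cc1`: 2790 nM

In this assay compound 1 gives 5210 nM, which lies within the scatter of both other compounds, so it cannot be ranked against either one. Compound 4 `[O-][S+](CCCN=C=S)Cc1ccccc1` has not yet been measured. It differs from compound 1 in one place: a group of 3 heavy atoms (1 carbon, 1 nitrogen, 1 sulfur; no ring) in place of a group of 4 heavy atoms (2 carbon, 1 nitrogen, 1 sulfur; no ring), on a saturated chain carbon, three bonds along the chain from a sulfur. The change is on a saturated chain carbon, three bonds along the chain from a sulfur.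

The measured steps all concern a group on an aromatic carbon: a 1.4-fold higher number from compound 1 to compound 2 (0.14 log units; within the scatter), a 1.9-fold lower number from compound 1 to compound 3 (0.27 log units; within the scatter) and a 2.6-fold lower number from compound 2 to compound 3 (0.41 log units; beyond the scatter). None of them alters the chain, so they bear on this change only indirectly, as a guide to how far small changes in this series have moved the number. With no measured chain change to suggest a direction, no step beyond the scatter is expected in this assay. The expected step is a 1.2-fold higher number from compound 1 to compound 4 (0.06 log units; within the scatter). Compound 4 is estimated at 6000 nM, with an expected range from 2800 nM to 13000 nM.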

Compound 4, half-maximal inhibitory concentration: 8890 nM
Estimate against measurement, compound 4: 1.5-fold (0.17 log units) below; the measured number falls inside the stated range.
By their numbers in this assay, from the lowest: compounds 3, 1, 2 and 4 (each within the scatter of the next, the first and the last beyond it).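

Compound 4 gives the only step shown that alters the chain rather than a group on the aromatic ring. In this assay, a 1.7-fold higher number from compound 1 to compound 4 (0.23 log units; within the scatter) shows that a group of 3 heavy atoms in place of a group of 4 heavy atoms, on a saturated chain carbon, three bonds along the chain from a sulfur, makes no change that can be told from the scatter. So, for this one pair, the number does not depend sharply on this chain change, and compound 4 stays in the same range as compound 1.

A longer chain, an amine in place of this end group, or the shorter chain combined with a methoxy or nitro group on the aromatic ring could still behave differently. Nothing measured here offers an explanation for this result.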